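The compounds below may be only part of what the source reports. "The series", "measured", "known", "first", "only" and "open" are said of these compounds alone.

Compound 1 `CCc1cccc(N2CCCC(=O)N2)c1`: 3000 nM
Compound 2 `O=C1CCCN(c2cccc(Cl)c2)N1`: 2500 nM
Compound 3 `O=C1CCCN(c2cccc(CO)c2)N1`: 53000 nM

Of the compounds shown here, three sharing one core have been measured in an assay on isolated protein for inhibition of Polyunsaturated fatty acid 5-lipoxygenase (Homo sapiens); a lower number here means a stronger inhibitor, a higher number a weaker inhibitor. Compound 1 and compound 2 give numbers that lie within the scatter of each other, as the step of a 1.2-fold lower number from compound 1 to compound 2 (0.08 log units; within the scatter) shows. Compound 3 stands at the highest number of the three: the step of an 18-fold higher number from compound 1 to compound 3 (1.25 log units; beyond the scatter) and the step of a 21-fold higher number from compound 2 to compound 3 (1.33 log units; beyond the scatter) are both large and beyond the scatter, so compound 3 is the weakest inhibitor among those measured.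

Compound 4 `CC(=O)c1cccc(N2CCCC(=O)N2)c1` has not yet been measured. It differs from compound 3 by acetyl in place of hydroxymethyl on an aromatic carbon. The two steps that bear on this are those leading into compound 3, an 18-fold higher number from compound 1 to compound 3 (1.25 log units; beyond the scatter) and a 21-fold higher number from compound 2 to compound 3 (1.33 log units; beyond the scatter), which show that the hydroxymethyl group is tied to a far higher number than either the ethyl or the chloro group. Compound 4 gives up the hydroxymethyl group, so compound 4 is expected to move back toward the lower numbers of compound 1 and compound 2, giving an expected step of a 6.6-fold lower number from compound 3 to compound 4 (0.82 log units; beyond the scatter). Compound 4 is therefore estimated at 8000 nM, with a range from 2500 nM to 30000 nM.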

Compound 4, half-maximal inhibitory concentration: 19000 nM
Compound 4: middle estimate off by 2.4-fold (0.38 log units), on the low side; the range from low to high includes it.
By their numbers in this assay, from the lowest: compounds 2 and 1 (each within the scatter of the next); then compound 4; then compound 3.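

In this assay, acetyl in place of hydroxymethyl on this aromatic carbon gives back only part of the loss seen with hydroxymethyl, with a 2.8-fold lower number from compound 3 to compound 4 (0.45 log units; beyond the scatter) as the step. Compound 4 still lies well above the two compounds with no oxygen in this group, with a 7.6-fold higher number from compound 2 to compound 4 (0.88 log units; beyond the scatter) and a 6.3-fold higher number from compound 1 to compound 4 (0.80 log units; beyond the scatter) as its steps. Dropping the hydrogen-bond donor of hydroxymethyl is therefore not enough to reach the numbers of chloro or ethyl, and among these four compounds both groups holding oxygen give higher numbers, with no compound going against this.

Nothing available explains these differences. The compounds shown leave open how a methoxy group, an amine or a carboxylic acid on this aromatic carbon would compare.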